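Dichlorophenyl sulfone variant of compound 1: expected binding

A few compounds are considered here, and "the series" means these few. Any claim that something is new, unique, unknown or untested is made for them only; others in the source may bear on it.

Compound 1 `CC1CCN(c2c(S(=O)(=O)c3ccc(Cl)cc3)cnc3cc(Cl)ccc23)CC1` stands highest of the three numbers in an assay on isolated protein for displacement of a labelled ligand from metabotropic glutamate receptor 5 (Homo sapiens), with a stated time of 60 min, tested at 1 uM (on this read-out lower numbers stand for less inhibition and higher numbers for more inhibition at the one concentration tested (going by the name of the read-out)), at 91%. Compound 2 `CC1CCN(c2c(S(=O)(=O)c3ccc(Cl)cc3)cnc3cc(F)ccc23)CC1` gives 90% in this assay; the step is a number 1 percentage points lower from compound 1 to compound 2 (within the scatter). Compound 3 `Cc1cc(C)cc(S(=O)(=O)c2cnc3cc(F)ccc3c2N2CCC(C)CC2)c1` gives 80% in this assay; the step is a number 10 percentage points lower from compound 2 to compound 3 (within the scatter). Compound 4 `CC1CCN(c2c(S(=O)(=O)c3ccc(Cl)c(Cl)c3)cnc3cc(Cl)ccc23)CC1` differs from compound 1 by chloro in place of hydrogen on an aromatic carbon. Of the measured steps, a number 10 percentage points lower from compound 2 to compound 3 (within the scatter) also alters the ring on the sulfonyl sulfur and stayed within the scatter, whereas a number 1 percentage points lower from compound 1 to compound 2 (within the scatter) concerns the other ring. No step beyond the scatter is therefore expected in this assay, and compound 1 already sits near the top of the read-out. For compound 4 the expected value in this assay is 88%, with a range from 74% to 97%. The estimated step is a number 3 percentage points lower from compound 1 to compound 4 (within the scatter).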

Compound 4, a percentage reported as inhibition, at one concentration (the size of the read-out at that concentration, not a potency): 89%
Estimate against measurement, compound 4: 1 percentage points below; the measured number falls inside the stated range.
By their numbers in this assay, from the lowest: compounds 3, 4, 2 and 1 (each within the scatter of the next, the first and the last beyond it).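

Notes on the sulfonyl aryl ring: in this assay, 4-chlorophenyl to 3,4-dichlorophenyl gives a number 2 percentage points lower from compound 1 to compound 4 (within the scatter). Unlike the whole-ring replacement in the earlier step, this change keeps the 4-chloro group and adds a second chloro, ortho to it, and the number is level with that of compound 1. Nothing available explains this result.

Still open, as far as these compounds go, is whether an amine or a carboxylic acid at this position would keep the number this high. Also open, from the compounds shown here alone, is whether the number would be level with the added chloro on compound 2.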